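The source may hold more compounds than are shown below. What is called first, only, known or untested is meant among the compounds shown, and "the series" means these compounds.

In a functional assay on OVCAR cells (Homo sapiens) for cytotoxicity, read by sulforhodamine B assay, with a stated time of 48 h (on this read-out higher numbers stand for weaker inhibition and lower numbers for stronger inhibition), three compounds of this series have been measured. Compound 1 `CC(=O)N1N=C(c2ccc(Br)cc2)CC1c1cccc(Cl)c1Cl` gives 39800 nM in this assay. Compound 2 `CC(=O)N1N=C(c2cccc([N+](=O)[O-])c2)CC1c1ccccc1` gives 9920 nM. Compound 3 `CC(=O)N1N=C(c2ccco2)CC1c1ccc([N+](=O)[O-])cc1` gives 23000 nM, which is the second highest of the three numbers; the value of compound 1 lies within the usual scatter of that of compound 3, while compound 2 gives a lower number than compound 3, a gap that lies beyond the scatter.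

Compound 4 `CC(=O)N1N=C(c2ccco2)CC1c1ccc(Cl)cc1` has not yet been measured in this assay. It differs from compound 3 in one place: chloro in place of nitro on an aromatic carbon. Within the data shown here, no pair among the measured compounds shows this exchange on its own, so there is no measured step to lean on. Since compound 3 gives 23000 nM, and the change is confined to a single substituent, no step beyond the scatter is expected in either direction. Compound 4 is therefore estimated to give 20000 nM in this assay, with a range from 7000 nM to 60000 nM. This estimate means an expected step of a 1.2-fold lower number from compound 3 to compound 4 (0.06 log units; within the scatter) that stays within the scatter.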

Compound 4, half-maximal inhibitory concentration: 31300 nM
The estimate for compound 4 lay 1.6-fold (0.19 log units) below the measured number; the measured number falls inside the stated range.
By their numbers in this assay, from the lowest: compound 2; then compounds 3, 4 and 1 (each within the scatter of the next).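

In this assay, among these compounds, chloro in place of nitro on an aromatic carbon, para to a large group, gives the first single-place step, a 1.4-fold higher number from compound 3 to compound 4 (0.13 log units; within the scatter), and that step stays within the scatter. With the rest of the molecule unchanged, this position therefore reads alike whether it carries nitro, with its three heavy atoms and two hydrogen-bond acceptors, or chloro, with one heavy atom and no hydrogen-bond acceptor. No measured evidence bears on why the two compounds read alike.

From the compounds shown here alone, whether any group at this position can move the number beyond the scatter remains open, for instance an amine, a carboxylic acid or a longer chain. Going by these compounds, whether the same exchange would read alike elsewhere also remains open, since it rests on this single pair.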